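From Amide Linker to Thiourea: Estimating a Tolyl Analogue

The compounds below may be only part of what the source reports. "The series", "measured", "known", "first", "only" and "open" are said of these compounds alone.

Compound 1 `COc1cc2ncnc(Nc3ccc(Br)cc3)c2cc1OCCCCC(=O)Nc1ccc(S(N)(=O)=O)cc1` in a functional assay on A549 cells (Homo sapiens) for antiproliferative activity, read by MTT assay, with a stated time of 72 h (a lower number here means a stronger inhibitor, a higher number a weaker inhibitor), gives > 40000 nM, a limit of the assay.
Compound 2 `COc1cc2ncnc(Nc3ccc(C)cc3)c2cc1OCCCCC(=O)Nc1ccc(S(N)(=O)=O)cc1` in this assay gives > 40000 nM, also a limit.
Compound 3 `NS(=O)(=O)c1ccc(NC(=S)Nc2ccc3ncnc(Nc4ccc(Cl)c(C(F)(F)F)c4)c3c2)cc1` in this assay gives 4500 nM.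

For the measured compounds named here, compound 3 holds the only number in this assay; the two other values sit at the limit of > 40000 nM in this assay, at which 2 of the 3 values shown sit. Compound 4 `Cc1ccc(Nc2ncnc3ccc(NC(=S)Nc4ccc(S(N)(=O)=O)cc4)cc23)cc1` differs from compound 3 by 4-methylphenyl in place of 4-chloro-3-(trifluoromethyl)phenyl on a nitrogen on an aromatic ring. Going by the values given here, the only measured step, a step that the two limits leave unreadable from compound 1 to compound 2, cannot be read because both ends sit at the limit of > 40000 nM in this assay, at which 2 of the 3 values shown sit. Among the compounds with values here, no measured step therefore bears on the change from compound 3 to compound 4, and the expectation rests on compound 3 alone. Compound 4 is expected to be a somewhat weaker inhibitor than compound 3, a step of a 2.7-fold higher number from compound 3 to compound 4 (0.43 log units; beyond the scatter). Compound 4 is estimated at 12000 nM, with a range from 2500 nM to 40000 nM.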

Compound 4, half-maximal inhibitory concentration: 2840 nM
For compound 4 the middle estimate is 4.2-fold (0.63 log units) above the measured one; measured number inside the range.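

In this assay, the change at this position, on a nitrogen on an aromatic ring, gives a 1.6-fold lower number from compound 3 to compound 4 (0.20 log units; within the scatter). The chlorine and the trifluoromethyl group are therefore not needed for a value in this range, since 4-methylphenyl, with fewer heavy atoms and carbon alone, serves as well here. Nothing shown gives a reason for this result.

As far as these compounds go, whether a 4-methoxyphenyl or a 4-aminophenyl group at this place would also stay within the scatter of compound 3 remains open.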